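This account rests on a few compounds, and the source may have more. Where it says the series, first, only, none or still open, it means among the compounds named here.

Working notes on the series. Compound 1 `CCn1c(CNc2ccccc2)nnc1SCC(=O)Nc1ccc(C(C)=O)cc1`, compound 2 `CCn1c(CNc2ccccc2)nnc1SCc1nc2cc(Cl)ccc2o1` and compound 3 `CCn1c(CNc2ccccc2)nnc1SCc1nc2cc(C)ccc2o1` have been measured in an assay on isolated protein for inhibition of long-chain fatty acid transport protein 1 (Homo sapiens); on this read-out higher numbers stand for weaker inhibition and lower numbers for stronger inhibition. In this assay compound 1 gives > 1000 nM, which is a limit of the assay and not a number. Compound 2 gives > 1000 nM in this assay, again a limit. Compound 3 likewise gives > 1000 nM in this assay, a limit. Compound 3 therefore stands nowhere definite on the numbers shown: every measured value sits at the limit of > 1000 nM in this assay, at which 3 of the 3 values shown sit. Going by the values given here, the only single change between measured compounds, a step that the two limits leave unreadable from compound 2 to compound 3, is a methyl in place of chloro on an aromatic carbon, and the two limits leave its size unreadable.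

Compound 4 `CC/C(=N/O)c1ccc2oc(CSc3nnc(CNc4ccccc4)n3CC)nc2c1` is to be measured in this assay. It differs from compound 3 by a group of 5 heavy atoms (3 carbon, 1 nitrogen, 1 oxygen; no ring) in place of one carbon atom, on an aromatic carbon. Among the compounds with values here, no measured step bears on this change: the step from compound 2 to compound 3 touches the same aromatic carbon but cannot be read, and none of the measured compounds carries a group of this kind. The expected step of an at least 1.2-fold lower number from compound 3 to compound 4 (0.09 log units; that floor lies within the scatter) is therefore set near no change, with wide uncertainty in both directions. Compound 4 is estimated at 800 nM, within 100 nM to 5000 nM, with a substantial chance that only a limit is again reported.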

Compound 4, half-maximal inhibitory concentration: 260 nM
Estimate against measurement, compound 4: 3.1-fold (0.49 log units) above; measured number inside the range.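

In this assay this aromatic carbon now gives a readable response: the group of 5 heavy atoms in place of methyl brings an at least 3.8-fold lower number from compound 3 to compound 4 (0.58 log units; beyond the scatter), and the same group in place of chloro brings an at least 3.8-fold lower number from compound 2 to compound 4 (0.58 log units; beyond the scatter). Going by these compounds alone, the step between chloro and methyl still cannot be read, so the earlier compounds said nothing about this position, whereas the change to compound 4 shows that a substituent on this carbon can carry a compound off the limit of this assay. Compound 4 is thus the only compound in the series with a value that is not a limit of the assay: the limit of > 1000 nM in this assay, at which 3 of the 4 values shown sit.

Going by these compounds, both steps are floors, so their true sizes stay open, as does the question of how much of the gain belongs to the hydroxyl hydrogen, the double bond or the chain length of the entering group. On these data alone, a ketone, an ethyl group, a primary amide or a carboxylic acid on the same aromatic carbon would separate these parts, and the other geometry about the double bond is equally open.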